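A few compounds are considered here, and "the series" means these few. Any claim that something is new, unique, unknown or untested is made for them only; others in the source may bear on it.

Among the measured compounds shown here, in a functional assay on the whole organism for inhibition, with Scenedesmus acutus as the target (on this read-out lower numbers stand for stronger inhibition and higher numbers for weaker inhibition), compound 1 `CCCOC(=O)c1cc(N2C(=O)C3=C(CCCC3)C2=O)c(F)cc1Cl` gives 33.1 nM, the lower of the two numbers measured so far, while compound 2 `CCCOC(=O)c1cc(N2C(=O)C3=C(CCCC3)C2=O)ccc1Cl`, with hydrogen in place of fluoro, gives 1120 nM. Compound 3 `C#CCOc1cc(N2C(=O)C3=C(CCCC3)C2=O)c(F)cc1Cl` keeps the fluoro and chloro groups of compound 1 and carries propargyloxy in place of propoxycarbonyl, on an aromatic carbon ortho to a chloro group and para to a fluoro group: propargyloxy in place of propoxycarbonyl on an aromatic carbon. For the measured compounds named here, the only measured step, a 34-fold higher number from compound 1 to compound 2 (1.53 log units; beyond the scatter), is large but concerns the fluoro group, which compound 3 retains. Going by the values given here, no measured step tests the new exchange, so compound 3 is expected to stay nearer compound 1, with only a small, uncertain move toward a lower number in this assay. The expected step is a 1.7-fold lower number from compound 1 to compound 3 (0.22 log units; within the scatter). For compound 3 the estimated value is 20 nM, with an expected range of 4 nM to 100 nM.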

Compound 3, half-maximal inhibitory concentration: 15.9 nM
Estimate against measurement, compound 3: 1.3-fold (0.10 log units) above; the range from low to high includes it.
By their numbers in this assay, from the lowest: compound 3; then compound 1; then compound 2.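

In this assay, propargyloxy in place of propoxycarbonyl on an aromatic carbon ortho to a chloro group and para to a fluoro group gives a 2.1-fold lower number from compound 1 to compound 3 (0.32 log units; beyond the scatter) and so shows, as the earlier pair could not, that inhibition at this level does not depend on propoxycarbonyl at this position. Among the compounds shown here, the exchange is modest beside the one at the fluoro group, which gave a 34-fold higher number from compound 1 to compound 2 (1.53 log units; beyond the scatter) in the same read-out. Nothing available on these compounds accounts for the direction of the new step.

The compounds shown leave open whether the gain belongs to propargyloxy itself or would also appear with methoxy, a longer chain such as butoxy, or a carboxylic acid at this carbon. They also leave open whether hydrogen in place of fluoro would cost as much in compound 3 as it did in compound 1.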